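Trading a thioether side chain for a hydroxyl one

A few compounds are considered here, and "the series" means these few. Any claim that something is new, unique, unknown or untested is made for them only; others in the source may bear on it.

Two hydroxamic acids sharing a core have been measured in a physicochemical assay for lipophilicity; a lower number here means a more polar compound, a higher number a more lipophilic compound. Compound 1 `COCCNC(=O)C[C@H](NC(=O)c1ccc(C#Cc2ccccc2)cc1)C(=O)NO` gives 2, and compound 2 `CSC[C@H](NC(=O)c1ccc(C#Cc2ccccc2)cc1)C(=O)NO` gives 3. Within the data shown here, compound 2 thus stands at the higher of the two numbers, with the only other value being that of compound 1; the step of a number 1.00 log units higher from compound 1 to compound 2 (beyond the scatter) is the single step known so far. Compound 3 `O=C(N[C@H](CO)C(=O)NO)c1ccc(C#Cc2ccccc2)cc1` differs from compound 2 by a group of 7 heavy atoms (3 carbon, 1 nitrogen, 3 oxygen; no ring) in place of a group of 8 heavy atoms (4 carbon, 1 nitrogen, 2 oxygen, 1 sulfur; no ring), on an amide-type nitrogen. Among the measured compounds shown here, no measured step matches this exact exchange, but the step from compound 1 to compound 2 shows that swapping the group on this part of the scaffold can move this assay by a modest amount, and the group entering in compound 3 carries more hydrogen-bond donors than the one leaving. Compound 3 is therefore expected to come out lower, by a number 1.40 log units lower from compound 2 to compound 3 (beyond the scatter), and its value is estimated at 1.6, within a range of 1 to 2.2.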

Compound 3, distribution coefficient: 2
The estimate for compound 3 lay 0.40 log units below the measured number; the range from low to high includes it.
By their numbers in this assay, from the lowest: compounds 1 and 3 (each within the scatter of the next); then compound 2.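

In this assay, replacing the group of 8 heavy atoms with the group of 7 heavy atoms on an amide-type nitrogen gives a number 1.00 log units lower from compound 2 to compound 3 (beyond the scatter), so a second, different exchange now separates compound 2 from the rest of the series. Compound 1 and compound 3 lie within the scatter of each other, although their side chains differ, which means two unlike groups can give readings that cannot be told apart in this assay. Nothing measured here accounts for the shift.

The compounds shown cannot tell whether the step follows from losing the sulfur or from the shorter group, since compound 2 and compound 3 differ in both. Going by these compounds, it also remains open whether an amine, a carboxylic acid or a longer chain ending in hydroxyl would read with compound 3 or with compound 2.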